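From trifluoroethyl to methoxy: a half-life question

The source may report more compounds than this note shows. Statements on the series, on what has been measured and on what is new or still open speak of the compounds shown alone.

Compound 1 `Cc1cc(CCCOc2c(C)cc(-c3noc(CC(F)(F)F)n3)cc2C)on1` gives 0.533 h
Compound 2 `Cc1cc(-c2noc(C3CC3)n2)cc(C)c1OCCCc1cc(CO)no1` gives > 2.5 h (a limit)

Among the compounds with values here, in an in vitro ADME assay on microsomes from liver (Simiiformes) (on this read-out lower numbers stand for a shorter-lived compound and higher numbers for a longer-lived compound), compound 1 gives 0.533 h as the only true number so far. Compound 2 reads > 2.5 h as a limit of the assay, not a number. Compound 3 `COc1nc(-c2cc(C)c(OCCCc3cc(C)no3)c(C)c2)no1` is still unmeasured, and its change from compound 1 is methoxy in place of 2,2,2-trifluoroethyl on an aromatic carbon in short, methoxy in place of 2,2,2-trifluoroethyl on an aromatic carbon. Within the data shown here, no measured one-place step exists to size this change, so the expectation rests on compound 1 at 0.533 h alone. The expected step of a 1.1-fold lower number from compound 1 to compound 3 (0.03 log units; within the scatter) stays within the scatter, with no direction favoured. Compound 3 is estimated at 0.5 h with 0.2 h to 1.3 h as the expected range.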

Compound 3, half-life: 0.55 h
For compound 3 the middle estimate is 1.1-fold (0.04 log units) below the measured one, and the stated range covers the measured number.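

In this assay, methoxy in place of 2,2,2-trifluoroethyl on an aromatic carbon gives a 1.0-fold higher number from compound 1 to compound 3 (0.01 log units; within the scatter). Within the data shown here, this is the first sized change at this position, and it shows that a smaller group with a hydrogen-bond acceptor and no fluorine can stand here with the two half-lives inside the usual scatter. Nothing shown gives a reason for this result. On these data alone, whether an amine or a carboxylic acid at this position would give a half-life beyond that scatter stays open. So does whether the same swap would behave alike on a different core.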